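The source may report more compounds than this note shows. Statements on the series, on what has been measured and on what is new or still open speak of the compounds shown alone.

Measured so far:
compound 1, `CC(NC(=O)c1ccc(C#Cc2ccccc2)cc1)C(=O)NO`: 29000 nM
compound 2, `O=C(NC1(C(=O)NO)CCOCC1)c1ccc(C#Cc2ccccc2)cc1`: 5000 nM

Among the compounds with values here, in a physicochemical assay for solubility (on this read-out higher numbers stand for higher solubility and lower numbers for lower solubility), compound 1 gives 29000 nM, the higher of the two numbers known here. Compound 2 gives 5000 nM in this assay, a lower number, and the two values lie apart by more than the usual scatter of repeated measurements. The two structures differ in more than one place, so the gap between them is left as it stands.

The next compound, compound 3, `CC(C)(NC(=O)c1ccc(C#Cc2ccccc2)cc1)C(=O)NO`, has not yet been measured. It differs from compound 1 in a single place: methyl in place of hydrogen on a saturated chain carbon bound to an amide-type nitrogen, a carbonyl carbon and a saturated chain carbon. Within the data shown here, with no comparable single-point step among the measured compounds, the expectation rests on compound 1 alone. The step from compound 1 to compound 3 is expected to be small and downward, a 1.5-fold lower number from compound 1 to compound 3 (0.16 log units; within the scatter), likely within the scatter. Compound 3 is estimated at 20000 nM in this assay, with a range from 7000 nM to 50000 nM.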

Compound 3, solubility: 182000 nM
The estimate for compound 3 lay 9.1-fold (0.96 log units) below the measured number; the whole stated range lies below it.
By their numbers in this assay, from the lowest: compound 2; then compound 1; then compound 3.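

Replacing hydrogen with methyl on the saturated chain carbon bound to an amide-type nitrogen, a carbonyl carbon and a saturated chain carbon gives a 6.3-fold higher number from compound 1 to compound 3 (0.80 log units; beyond the scatter) in this assay. Within the data shown here, this is the first single-place step, and it shows that this position can respond to a change of just 1 heavy atom, with a step that lies beyond the scatter and runs upward. Nothing available here accounts for the size or direction of this step.

From the compounds shown here alone, it remains open whether an ethyl group, a longer chain, an amine or a carboxylic acid at this same carbon would move the number in the same direction. This one pair also cannot show whether the same methyl step would recur on a different core.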